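Chain Lengthening at the Aryl Ether in Three Acetophenones

A few compounds are considered here, and "the series" means these few. Any claim that something is new, unique, unknown or untested is made for them only; others in the source may bear on it.

Compound 1 `CCCCOc1cc(OC)c(Br)cc1C(C)=O`: 38200000 nM
Compound 2 `CCCCCCOc1cc(OC)c(Br)cc1C(C)=O`: 34000000 nM
Compound 3 `CCCCCCCCOc1cc(OC)ccc1C(C)=O`: 21200000 nM

Of the compounds shown here, three have been measured in a functional assay, with stated times of 30 s and 6 min, in the presence of a further agent that is not named here; on this read-out higher numbers stand for weaker inhibition and lower numbers for stronger inhibition. Compound 1 `CCCCOc1cc(OC)c(Br)cc1C(C)=O` gives 38200000 nM in this assay. Compound 2 `CCCCCCOc1cc(OC)c(Br)cc1C(C)=O` differs from it by ethyl in place of hydrogen on a saturated chain carbon, four bonds along the chain from an oxygen on an aromatic ring, and in this assay compound 2 gives 34000000 nM. The step of a 1.1-fold lower number from compound 1 to compound 2 (0.05 log units; within the scatter) is small, and the two values cannot be told apart.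

Compound 3 `CCCCCCCCOc1cc(OC)ccc1C(C)=O` has a different core; the difference between the core of compound 1 and the core of compound 3 is not broken down here. In this assay compound 3 gives 21200000 nM, which sits within the scatter of both compound 1 and compound 2, so no ordering among the three can be claimed.

Compound 4 `CCCCCCCCCCOc1cc(OC)ccc1C(C)=O` is not yet measured. It differs from compound 3 by ethyl in place of hydrogen on a saturated chain carbon, eight bonds along the chain from an oxygen on an aromatic ring. This is the same kind of change as that from compound 1 to compound 2, though the place is not the same: there the ethyl enters four bonds along the chain from the oxygen on the aromatic ring, here eight bonds along the chain. Because a 1.1-fold lower number from compound 1 to compound 2 (0.05 log units; within the scatter) was flat, the expected step is a 1.2-fold lower number from compound 3 to compound 4 (0.07 log units; within the scatter), again within the scatter. Compound 4 is accordingly estimated at 18000000 nM, with a range from 8000000 nM to 40000000 nM.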

Compound 4, half-maximal inhibitory concentration: 26600000 nM
Beside the measured number, compound 4's estimate is 1.5-fold (0.17 log units) below it; the measured number falls inside the stated range.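

Ethyl in place of hydrogen on a saturated chain carbon, eight bonds along the chain from an oxygen on an aromatic ring, gives a 1.3-fold higher number from compound 3 to compound 4 (0.10 log units; within the scatter) in this assay, so the two values cannot be told apart. Set beside the earlier step, the same change is flat on both cores, even though it falls at a different place on the chain in each: the same change on two cores in this assay, a 1.1-fold lower number (0.05 log units; within the scatter) from compound 1 to compound 2 and a 1.3-fold higher number (0.10 log units; within the scatter) from compound 3 to compound 4, 1.4-fold (0.15 log units) apart, within the scatter of two such steps This shows only that the change left no readable mark on either core, with a single pair per core in a single assay; it does not show that the change would stay flat on a further core or at another place on the chain, and with no step beyond the scatter there is no real effect whose transfer could be judged.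

The compounds shown leave open whether an amine or a carboxylic acid at the end of the chain, in place of the plain saturated chains, would shift the number in this assay beyond the scatter. They also leave open whether a longer chain than that of compound 4 would stay as flat as the steps seen here.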